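Replacing the aryl group on sulfur in a benzamide series

The source may hold more compounds than are shown below. What is called first, only, known or untested is meant among the compounds shown, and "the series" means these compounds.

Measured compounds:
compound 1 `Cc1ccc(SCc2ccc(/C=C/C(=O)Nc3ccccc3N)cc2)cc1`: 22.9%
compound 2 `COc1ccc(SCc2ccc(C(=O)Nc3ccccc3N)cc2)cc1`: 10.2%
compound 3 `Nc1ccccc1NC(=O)/C=C/c1ccc(CSc2cccc3ccccc23)cc1`: 1.55%

In a functional assay on A-375 cells (Homo sapiens) for inhibition, read by CCK-8 assay, with a stated time of 72 h, tested at 2 uM (on this read-out lower numbers stand for less inhibition of growth and higher numbers for more inhibition of growth at the one concentration tested), compound 2 gives 10.2%. Compound 1 gives a number beyond the scatter above it, while compound 3 lies within the scatter of compound 2. Compound 4 `Nc1ccccc1NC(=O)c1ccc(CSCCc2ccccc2)cc1` differs from compound 2 in one place: phenethyl in place of 4-methoxyphenyl on a sulfur. Going by the values given here, the only measured step at this sulfur is a number 21.4 percentage points lower from compound 1 to compound 3 (beyond the scatter), a modest fall, though with a different entering group and a different linker. This gives little ground for a large move; a step within the scatter or a modest fall is expected, a number 2.2 percentage points lower from compound 2 to compound 4 (within the scatter). Compound 4 is therefore estimated at 8% in this assay, between 0% and 22%.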

Compound 4, percent growth inhibition at one concentration: 21.8%
For compound 4 the middle estimate is 13.8 percentage points below the measured one; the measured number falls inside the stated range.
By their numbers in this assay, from the lowest: compounds 3 and 2 (each within the scatter of the next); then compounds 4 and 1 (each within the scatter of the next).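

In this assay, going by these compounds alone, phenethyl in place of 4-methoxyphenyl on a sulfur gives a number 11.6 percentage points higher from compound 2 to compound 4 (beyond the scatter) and this is the first rise seen at this sulfur. Within the data shown here, the only earlier step there was a fall, so the position is now seen to move in both directions. It also shows that the ring need not sit directly on the sulfur to keep growth inhibition.

The compounds shown leave open whether the rise follows the two-carbon chain or the loss of the methoxy group, which an unsubstituted phenyl, a benzyl or a 3-phenylpropyl group on the sulfur would separate. No evidence at hand bears on the reason for this step.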